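The source may report more compounds than this note shows. Statements on the series, on what has been measured and on what is new or still open speak of the compounds shown alone.

Compound 2 `CCS(=O)(=O)Nc1cc(-c2ccc3ncnc(Nc4ccc(F)nc4)c3c2)cnc1OC` gives 5240 nM in a functional assay on SK-HEP1 cells (Homo sapiens) for cytotoxicity, read by sulforhodamine B assay, with a stated time of 72 h (a lower number here means a stronger inhibitor, a higher number a weaker inhibitor), and stands as the higher of the two numbers measured; compound 1 `CCS(=O)(=O)Nc1cc(-c2ccc3ncnc(Nc4cccc(F)c4)c3c2)cnc1OC` gives 1850 nM. Within the data shown here, the one measured step, a 2.8-fold higher number from compound 1 to compound 2 (0.45 log units; beyond the scatter), swapped 3-fluorophenyl for 6-fluoropyridin-3-yl on the nitrogen attached to the shared core. Among the measured compounds shown here, compound 3 `CCS(=O)(=O)Nc1cc(-c2ccc3ncnc(Nc4ccc(OC)nc4)c3c2)cnc1OC` keeps that pyridine ring but carries methoxy in place of fluoro on an aromatic carbon, a change no measured pair speaks to directly. For the measured compounds named here, with no close precedent, compound 3 is expected to stay near compound 2, with a 1.3-fold lower number from compound 2 to compound 3 (0.12 log units; within the scatter) as the estimated step. The estimate for compound 3 is 4000 nM, expected between 1500 nM and 12000 nM.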

Compound 3, half-maximal inhibitory concentration: 3440 nM
Beside the measured number, compound 3's estimate is 1.2-fold (0.07 log units) above it; the measured number falls inside the stated range.
By their numbers in this assay, from the lowest: compounds 1, 3 and 2 (each within the scatter of the next, the first and the last beyond it).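

In this assay methoxy in place of fluoro on this aromatic carbon, next to the ring nitrogen, gives a 1.5-fold lower number from compound 2 to compound 3 (0.18 log units; within the scatter) and so shows no clear effect on the number here. With 6-methoxypyridin-3-yl in place of 3-fluorophenyl, the result is a 1.9-fold higher number from compound 1 to compound 3 (0.27 log units; within the scatter) and so, unlike a 2.8-fold higher number from compound 1 to compound 2 (0.45 log units; beyond the scatter) for the fluoro compound, this step cannot be told from repeat scatter. No measurement given here explains these numbers.

Going by these compounds, whether an amine or a longer chain such as ethoxy at this position would give a step beyond the scatter stays open.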